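The compounds below may be only part of what the source reports. "The series", "measured", "known", "first", "only" and "open" are said of these compounds alone.

Working notes on the series. For the measured compounds named here, compound 1 `O=C1C(=O)N(CCCn2cc(COc3cc(=O)oc4ccccc34)nn2)c2ccc(Br)cc21` carries a bromo group on its core and, in a functional assay on HCT-116 cells (Homo sapiens) for inhibition, read by sulforhodamine B assay, with a stated time of 48 h, tested at 50 uM (a lower number here means less inhibition of growth, a higher number more inhibition of growth at the concentration tested), compound 1 gives 66%, the higher of the two numbers measured so far. Compound 2 `O=C1C(=O)N(CCCCCn2cc(COc3cc(=O)oc4ccccc34)nn2)c2ccc([N+](=O)[O-])cc21` pairs a nitro group with a five-carbon chain to the triazole, and in this assay compound 2 gives 29%, which lies beyond the scatter below compound 1. Compound 2 differs from compound 1 in two places, so its gap to compound 1 is not attributed to either change alone.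

Going by the values given here, compound 3 `O=C1C(=O)N(CCCn2cc(COc3cc(=O)oc4ccccc34)nn2)c2ccc([N+](=O)[O-])cc21` takes only one of those changes relative to compound 1: nitro in place of bromo on an aromatic carbon. With no single-change comparison measured, the size of the step to compound 3 in this assay is uncertain; a downward step of moderate size is expected, though one within the scatter cannot be excluded. Compound 3 is estimated to give 48%, with a range from 28% to 66%, meaning an expected step of a number 18 percentage points lower from compound 1 to compound 3 (beyond the scatter).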

Compound 3, percent growth inhibition at one concentration: 60%
The estimate for compound 3 lay 12 percentage points below the measured number, within the range that was stated.
By their numbers in this assay, from the lowest: compound 2; then compounds 3 and 1 (each within the scatter of the next).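

At this aromatic carbon, nitro in place of bromo gives a number 6 percentage points lower from compound 1 to compound 3 (within the scatter) in this assay, so the two groups cannot be told apart here. Compound 3 shares its nitro group with compound 2 and differs from it only in the chain to the triazole; compound 3 gives 60% and compound 2 gives 29% in this assay, so nitro alone does not go with the low number of compound 2. Nothing on hand explains how bromo and nitro compare at this carbon.

As far as these compounds go, whether an amine or a carboxylic acid on this aromatic carbon would keep the number at this level remains open. Also open, from the compounds shown here alone, is how the longer chain of compound 2 reads with bromo on the core, and how a still longer chain reads.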